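Moving the methoxy group: compound 3 to compound 4

This account rests on a few compounds, and the source may have more. Where it says the series, first, only, none or still open, it means among the compounds named here.

Measured compounds in a functional assay on Ehrlich cells (Mus musculus) for antiproliferative activity, read by trypan blue exclusion, with a stated time of 2 h, tested at 50 ug/mL; on this read-out lower numbers stand for a weaker effect and higher numbers for a stronger effect at the one concentration tested:
compound 1 `N#CC1=C(N)N(c2ccc(S(N)(=O)=O)cc2)C2=C(C(=O)CCC2)C1c1ccccc1`: 40%
compound 2 `Cc1ccc(C2C(C#N)=C(N)N(c3ccc(S(N)(=O)=O)cc3)C3=C2C(=O)CCC3)cc1`: 50%
compound 3 `COc1ccccc1C1C(C#N)=C(N)N(c2ccc(S(N)(=O)=O)cc2)C2=C1C(=O)CCC2`: 0%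

Compound 3 stands lowest of the three; its steps to compound 1 and to compound 2 are both beyond the scatter. Compound 4 `COc1ccc(C2C(C#N)=C(N)N(c3ccc(S(N)(=O)=O)cc3)C3=C2C(=O)CCC3)cc1` differs from compound 3 in one place: 4-methoxyphenyl in place of 2-methoxyphenyl on a saturated ring carbon. Of the measured steps, a number 40 percentage points lower from compound 1 to compound 3 (beyond the scatter) and a number 50 percentage points lower from compound 2 to compound 3 (beyond the scatter) bear on it, both large losses tied to the 2-methoxyphenyl group, while a number 10 percentage points higher from compound 1 to compound 2 (within the scatter) shows a 4-methylphenyl group tolerated. For the measured compounds named here, no step for 4-methoxyphenyl against hydrogen exists. Compound 4 is therefore expected to recover a good part of the loss, with a number 35 percentage points higher from compound 3 to compound 4 (beyond the scatter). The estimate for compound 4 in this assay is 35%, within 5% to 60%.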

Compound 4, a percentage reported as activity, at one concentration (the size of the read-out at that concentration, not a potency): 90%
Compound 4: middle estimate off by 55 percentage points, on the low side; the measured number lies above the stated range.
By their numbers in this assay, from the lowest: compound 3; then compounds 1 and 2 (each within the scatter of the next); then compound 4.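

In this assay, the site of the methoxy group on the phenyl ring decides the outcome: 4-methoxyphenyl in place of 2-methoxyphenyl gives a number 90 percentage points higher from compound 3 to compound 4 (beyond the scatter). Methoxy is thus no liability in itself: in place of hydrogen it gives a number 50 percentage points higher from compound 1 to compound 4 (beyond the scatter), and in place of methyl it gives a number 40 percentage points higher from compound 2 to compound 4 (beyond the scatter). Nothing available explains why the two methoxyphenyl groups differ so sharply. Going by these compounds, it remains open whether an ethoxy, hydroxy or dimethylamino group in place of the methoxy of 4-methoxyphenyl would hold this level. A read-out at one concentration also gives no potency for compound 4.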